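This account rests on a few compounds, and the source may have more. Where it says the series, first, only, none or still open, it means among the compounds named here.

Of the compounds shown here, two that share one core have been tested in a functional assay on CHO-K1 cells for antagonist activity at C-X-C chemokine receptor type 3 (Homo sapiens), read by FLIPR, with a stated time of 10 min, in the presence of a further agent that is not named here; a higher number here means a weaker inhibitor, a lower number a stronger inhibitor. Compound 1 `COC1CCN(CC(=O)N2CCN(c3sc(C(F)(F)F)nc3-c3nc4ccccc4[nH]3)C[C@H]2C)C1` gives 42 nM. Among the measured compounds shown here, compound 2 `C[C@@H]1CN(c2sc(C(F)(F)F)nc2-c2nc3ccccc3[nH]2)CCN1C(=O)CN1CCC(F)(F)CC1` gives 15 nM, the lowest of the two numbers, and the only measured step, a 2.8-fold lower number from compound 1 to compound 2 (0.45 log units; beyond the scatter), separates it from compound 1.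

Compound 3 `C[C@@H]1CN(c2sc(C(F)(F)F)nc2-c2nc3ccccc3[nH]2)CCN1C(=O)Cn1cc(C2CCN(C)CC2)cn1` is the next compound, not yet measured. It differs from compound 2 in one place: 4-(1-methylpiperidin-4-yl)-1H-pyrazol-1-yl in place of 4,4-difluoropiperidin-1-yl on a saturated chain carbon bound to a carbonyl carbon. For the measured compounds named here, the single measured step bears on this change only loosely, since it exchanged one saturated ring for another at the same place, whereas the change to compound 3 brings in a five-membered aromatic ring carrying a further six-membered ring. The measured step was of modest size, and no other comparison at this place is available, so the direction of the new step cannot be read from the data. The expectation is therefore a number for compound 3 near that of compound 2, with the step from compound 2 to compound 3 estimated as a 1.7-fold higher number from compound 2 to compound 3 (0.22 log units; within the scatter), within a wide range. In this assay, compound 3 is expected to give about 25 nM, estimated between 6 nM and 100 nM.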

Compound 3, half-maximal inhibitory concentration: 15 nM
For compound 3 the middle estimate is 1.7-fold (0.22 log units) above the measured one; measured number inside the range.
By their numbers in this assay, from the lowest: compounds 2 and 3 (each within the scatter of the next); then compound 1.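

In this assay the exchange of 4,4-difluoropiperidin-1-yl for 4-(1-methylpiperidin-4-yl)-1H-pyrazol-1-yl gives no change at the digits printed from compound 2 to compound 3 (within the scatter) even though the entering group has more heavy atoms, carries no fluorine and adds a five-membered aromatic ring, so this place on a saturated chain carbon bound to a carbonyl carbon accepts two very different groups with the same reading. The same group set against 3-methoxypyrrolidin-1-yl gives a 2.8-fold lower number from compound 1 to compound 3 (0.45 log units; beyond the scatter) and thus matches the step already seen with 4,4-difluoropiperidin-1-yl, which shows that the gain over compound 1 does not depend on one particular replacement. No measurement shown here accounts for why these two unlike groups read alike.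

The compounds shown leave open which part of the entering group matters, and a plain 1H-pyrazol-1-yl group at this place would separate the aromatic ring from the 1-methylpiperidin-4-yl ring it carries. They also leave open how far this tolerance extends, such as whether a carboxylic acid or an open-chain dimethylamino group on the same chain carbon would read like compound 2 and compound 3 or like compound 1.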